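A few compounds are considered here, and "the series" means these few. Any claim that something is new, unique, unknown or untested is made for them only; others in the source may bear on it.

Measured so far in a physicochemical assay for lipophilicity; a lower number here means a more polar compound, a higher number a more lipophilic compound:
- compound 1 `C[C@H]1CC[C@@H]2[C@@H](OC(=O)[C@]23CC(c2c(Cl)cccc2Cl)=NO3)[C@]2(C)C(=O)C=C[C@@]12O` gives 2.67 here
- compound 2 `Cc1ccccc1C1=NO[C@]2(C1)C(=O)O[C@@H]1[C@H]2CC[C@H](C)[C@]2(O)C=CC(=O)[C@@]12C` gives 1.86 here

For the measured compounds named here, compound 2 is the lower of these two numbers, with compound 1 the only neighbour. The next compound is compound 3 `C[C@H]1CC[C@@H]2[C@@H](OC(=O)[C@]23CC(c2ccc(C#N)cc2)=NO3)[C@]2(C)C(=O)C=C[C@@]12O`, not yet measured. The change is 4-cyanophenyl in place of 2-methylphenyl on a carbon with a double bond to nitrogen, with 4-cyanophenyl in place of 2-methylphenyl on a carbon with a double bond to nitrogen.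

Going by the values given here, one measured step bears on this, at the same place: a number 0.81 log units lower from compound 1 to compound 2 (beyond the scatter), modest and beyond the scatter. It involves other groups, so it indicates the size a change here can reach and gives no direction. Only the entering group has a hydrogen-bond acceptor, so a fall is tentatively expected. The step expected is a number 0.46 log units lower from compound 2 to compound 3 (beyond the scatter) in this assay, smaller than the measured one. For compound 3 the estimated value is 1.4, with 0.95 to 1.9 as the expected range.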

Compound 3, partition coefficient: 1.17
Compound 3: middle estimate off by 0.23 log units, on the high side; the measured number falls inside the stated range.
By their numbers in this assay, from the lowest: compound 3; then compound 2; then compound 1.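

In this assay, a second change on the carbon with a double bond to nitrogen gives a number 0.69 log units lower from compound 2 to compound 3 (beyond the scatter) and shows that the step seen earlier at this place was not a single case. Taken from the 2,6-dichlorophenyl end of the set, the change to 4-cyanophenyl gives a number 1.50 log units lower from compound 1 to compound 3 (beyond the scatter). This reaches well past the modest step between compound 1 and compound 2, which means this one place can span a large part of the scale. The order of the three compounds is established, but no measurement here explains it.

For the compounds shown here, with only three substituted phenyl groups in hand, the part played by the nitrile cannot be separated from the loss of the methyl group, and plain phenyl would be needed for that comparison. As far as these compounds go, how a group without a phenyl ring, such as a primary amine or a carboxylic acid, would read at this place in this assay also remains open.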